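From a Free Amine to a Nitrophenylcarbonyl Amide

This account rests on a few compounds, and the source may have more. Where it says the series, first, only, none or still open, it means among the compounds named here.

Compound 1 `O=C(Nc1nc(-c2ccccc2)nc2c1nnn2Cc1ccccc1)c1cccc([N+](=O)[O-])c1` gives 77 nM in an assay (strain Wistar) for displacement of a labelled ligand from adenosine receptor A1 (Rattus norvegicus), read by scintillation counting; a higher number here means a weaker inhibitor, a lower number a stronger inhibitor.
Compound 2 `Nc1nc(-c2ccccc2)nc2c1nnn2Cc1ccccc1` gives 5.6 nM in this assay.

Going by the values given here, compound 2 stands at the lowest of the two numbers measured so far; its nearest neighbour is compound 1, whose number is higher by a 14-fold lower number from compound 1 to compound 2 (1.14 log units; beyond the scatter) read in the reverse direction. Among the compounds with values here, the only measured step, a 14-fold lower number from compound 1 to compound 2 (1.14 log units; beyond the scatter), is therefore the sole guide available, and it is large: removing the (3-nitrophenyl)carbonyl group from the nitrogen on the aromatic ring lowered the number well beyond the scatter.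

Compound 3 `O=C(Nc1nc(-c2ccccc2)nc2c1nnn2Cc1ccccc1)c1ccc([N+](=O)[O-])cc1` has not yet been measured. It differs from compound 2 as follows: (4-nitrophenyl)carbonyl in place of hydrogen on a nitrogen on an aromatic ring. Within the data shown here, this is the same kind of change as the one separating compound 1 from compound 2, differing only in the name of the entering group. Since the step of a 14-fold lower number from compound 1 to compound 2 (1.14 log units; beyond the scatter) was large, the expectation for compound 3 in this assay is a step of about the same size but in the opposite direction, a 13-fold higher number from compound 2 to compound 3 (1.10 log units; beyond the scatter), landing near the number of compound 1. The estimate for compound 3 is 70 nM, with a range from 25 nM to 200 nM.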

Compound 3, inhibition constant: 24 nM
The estimate for compound 3 lay 2.9-fold (0.46 log units) above the measured number; measured number outside the range, below it.
By their numbers in this assay, from the lowest: compound 2; then compound 3; then compound 1.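

In this assay, going by these compounds alone, placing (4-nitrophenyl)carbonyl on the nitrogen on an aromatic ring gives a 4.3-fold higher number from compound 2 to compound 3 (0.63 log units; beyond the scatter) and thus a smaller penalty than the single earlier step suggested, while exchanging 3-nitrophenyl for 4-nitrophenyl on the carbonyl carbon alone gives a 3.2-fold lower number from compound 1 to compound 3 (0.51 log units; beyond the scatter) and separates the two amides. The number at this nitrogen therefore depends on more than the presence of a carbonyl: the placement of the nitro group on the entering phenyl ring also changes it, something the first pair could not reveal. Even so, neither amide reaches the number of compound 2, so among these three compounds, adding a nitrophenylcarbonyl group at this position raises the number in both cases.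

The compounds shown leave open whether the trend would hold for an amide with a plain phenyl ring, with a methoxy group or carboxylic acid in place of the nitro group, or with a simple acetyl group on the same nitrogen. Nothing available here explains why the two nitrophenylcarbonyl groups differ.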